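The source may report more compounds than this note shows. Statements on the series, on what has been measured and on what is new or still open speak of the compounds shown alone.

The measured compounds:

Compound 1, `O=[N+]([O-])c1ccc(CN2CCC(n3cc(CC(OCc4cc(-c5ccc(Br)cc5)no4)c4ccc(Br)cc4)nn3)CC2)cc1`, gives 4000 nM in a functional assay on MCF7 cells (Homo sapiens) for cytotoxicity, with a stated time of 48 h; on this read-out higher numbers stand for weaker inhibition and lower numbers for stronger inhibition.
Compound 2, `COc1ccc(-c2cc(COC(Cc3cn(C4CCN(Cc5ccc([N+](=O)[O-])cc5)CC4)nn3)c3ccc(Br)cc3)on2)cc1`, gives 4000 nM.
Compound 3, `O=[N+]([O-])c1ccc(CN2CCC(n3cc(CC(OCc4cc(-c5cccc(Br)c5)no4)c4ccc(Br)cc4)nn3)CC2)cc1`, gives 6000 nM.

The three compounds differ only in one aryl group, and their numbers all lie within the usual scatter of one another. Compound 3 therefore stands apart from neither of its neighbours: the step of a 1.5-fold higher number from compound 1 to compound 3 (0.18 log units; within the scatter) and the step of a 1.5-fold higher number from compound 2 to compound 3 (0.18 log units; within the scatter) are both small, and so is the step of no change at the digits printed from compound 1 to compound 2 (within the scatter) between the other two.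

Compound 4, `N#Cc1cccc(-c2cc(COC(Cc3cn(C4CCN(Cc5ccc([N+](=O)[O-])cc5)CC4)nn3)c3ccc(Br)cc3)on2)c1`, is the next member of the series and has not yet been measured. It differs from compound 3 in one place: cyano in place of bromo on an aromatic carbon. The substituent sits meta to a large group, on a six-membered aromatic ring of carbon only.

All three known steps change the same aryl group, and none of them moved the number beyond the scatter. On that basis the exchange of bromo for cyano in compound 4 is expected to give a step of a 1.2-fold lower number from compound 3 to compound 4 (0.08 log units; within the scatter), that is, none beyond the scatter. Compound 4 is accordingly estimated at 5000 nM, with a range from 2000 nM to 15000 nM.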

Compound 4, half-maximal inhibitory concentration: 2000 nM
Estimate against measurement, compound 4: 2.5-fold (0.40 log units) above; the range from low to high includes it.
By their numbers in this assay, from the lowest: compounds 4, 1, 2 and 3 (each within the scatter of the next, the first and the last beyond it).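

In this assay, among the compounds shown here, the exchange of 3-bromophenyl for 3-cyanophenyl gives the first step to pass beyond the scatter (a 3.0-fold lower number from compound 3 to compound 4 (0.48 log units; beyond the scatter)), so a change on this aromatic carbon, meta to a large group, can move the number, if only modestly. The effect holds for this one pair alone, since the other two steps to compound 4 (a 2.0-fold lower number from compound 2 to compound 4 (0.30 log units; within the scatter) and a 2.0-fold lower number from compound 1 to compound 4 (0.30 log units; within the scatter)) stay within the scatter, and compound 4 therefore stands clear of compound 3 but not of compound 1 or compound 2. Nothing measured here accounts for the step from bromo to cyano.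

The compounds shown leave open whether the step belongs to the nitrile itself or to its position, as a 4-cyanophenyl group at the same place would tell. They also leave open where a plain phenyl group, or a 3-substituted ring carrying an amine or a carboxylic acid, would fall relative to compound 3 and compound 4.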